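This account rests on a few compounds, and the source may have more. Where it says the series, first, only, none or still open, it means among the compounds named here.

Of the compounds shown here, three sharing one core have been measured in an assay for inhibition of histone acetyltransferase KAT2B (Homo sapiens), read by fluorescence; on this read-out higher numbers stand for weaker inhibition and lower numbers for stronger inhibition. Compound 1 `O=c1c2cc([N+](=O)[O-])cnc2sn1-c1ccc(Br)cc1` gives 4910 nM, compound 2 `Cc1cnc2sn(-c3ccc(Br)cc3)c(=O)c2c1` gives 2990 nM, and compound 3 `O=c1c2cccnc2sn1-c1ccc(Br)cc1` gives 4430 nM. Compound 1 has the highest of the three numbers, with compound 3 nearest and compound 2 furthest, but both gaps lie within the scatter of repeated measurements, so the three compounds cannot be told apart on this read-out. All the changes among them concern the same aromatic carbon of the core: a 1.6-fold lower number from compound 1 to compound 2 (0.22 log units; within the scatter); a 1.1-fold lower number from compound 1 to compound 3 (0.04 log units; within the scatter); a 1.5-fold higher number from compound 2 to compound 3 (0.17 log units; within the scatter).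

For the measured compounds named here, compound 4 `COc1ccc(-n2sc3ncc([N+](=O)[O-])cc3c2=O)cc1` differs from compound 1 at another position. methoxy in place of bromo on an aromatic carbon None of the measured steps touches this position, so no measured step bears directly on the change from compound 1 to compound 4. What the measured compounds do show is that variation elsewhere on the core has so far left the numbers in this assay within the scatter. Compound 4 is therefore expected to stay close to compound 1, with no step beyond the scatter. The step expected for compound 4 is a 1.1-fold lower number from compound 1 to compound 4 (0.04 log units; within the scatter). The estimate for compound 4 is 4500 nM, with a range from 1500 nM to 13000 nM.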

Compound 4, half-maximal inhibitory concentration: 3420 nM
Beside the measured number, compound 4's estimate is 1.3-fold (0.12 log units) above it, within the range that was stated.
By their numbers in this assay, from the lowest: compounds 2, 4, 3 and 1 (each within the scatter of the next).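

For the compounds shown here, with compound 4 the account reaches, for the first time, the aromatic carbon para to a large group on the six-membered aromatic ring of carbon only, a place on which the earlier compounds gave no information. In this assay, methoxy in place of bromo gives a 1.4-fold lower number from compound 1 to compound 4 (0.16 log units; within the scatter), so exchanging this single bromine atom for a group of two heavy atoms that brings in one hydrogen-bond acceptor does not separate compound 4 from compound 1 on this read-out. Every step now measured, at either of the two places varied, lies within the scatter, and no measurement given here offers an explanation for this result.

On these data alone, whether an amine, a carboxylic acid or a longer chain on this same aromatic carbon would give a step beyond the scatter remains open. Also open, as far as these compounds go, is whether methoxy in place of bromo would give a similar step on the cores of compound 2 and compound 3, which carry methyl and hydrogen where compound 1 carries nitro.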